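The compounds below may be only part of what the source reports. "The series", "measured", "known", "first", "only" and "open" are said of these compounds alone.

Of the compounds shown here, three with a shared core have been measured in an assay on membranes from HeLa cells for displacement of a labelled ligand from adenosine receptor A3 (Homo sapiens), read by scintillation counting, with a stated time of 180 min, tested at 1 uM (on this read-out lower numbers stand for less inhibition and higher numbers for more inhibition at the one concentration tested (going by the name of the read-out)), and each carries a different five-membered aromatic ring on a saturated ring carbon. Compound 1 `CCCOC(=O)C1=C(C)NC(=O)NC1c1ccco1` gives 3%. Compound 2 `CCCOC(=O)C1=C(C)NC(=O)NC1c1ccoc1` gives 11%, and compound 3 `CCCOC(=O)C1=C(C)NC(=O)NC1c1ccsc1` gives 6%. The steps of a number 8 percentage points higher from compound 1 to compound 2 (within the scatter), a number 3 percentage points higher from compound 1 to compound 3 (within the scatter) and a number 5 percentage points lower from compound 2 to compound 3 (within the scatter) all sit inside the usual scatter of repeated measurements, so the three numbers cannot be told apart, and compound 1 simply shares this low level with the other two.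

Compound 4 `CCC(CC)OC(=O)C1=C(C)NC(=O)NC1c1ccco1` differs from compound 1 in another place, on the ester chain: ethyl in place of hydrogen on a saturated chain carbon bound to an oxygen next to a carbonyl group and a saturated chain carbon. Among the measured compounds shown here, none of the measured steps changes that chain, so no step bears directly on it; every change that has been measured, each within the scatter, concerns the ring on the saturated ring carbon instead. With all three measured compounds at a low level and no evidence that the chain matters, compound 4 is expected to stay at a similar level, with 6% as the estimate and a range from 0% to 20%. The estimated step of a number 3 percentage points higher from compound 1 to compound 4 (within the scatter) would lie within the scatter.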

Compound 4, a percentage reported as inhibition, at one concentration (the size of the read-out at that concentration, not a potency): 1%
For compound 4 the middle estimate is 5 percentage points above the measured one, within the range that was stated.
By their numbers in this assay, from the lowest: compounds 4, 1, 3 and 2 (each within the scatter of the next).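

Putting ethyl in place of hydrogen on the saturated chain carbon bound to the ester oxygen, which turns propoxy into (pentan-3-yl)oxy, gives in this assay a number 2 percentage points lower from compound 1 to compound 4 (within the scatter). Among the compounds shown here, this is the first measured change on the ester chain rather than on the five-membered ring, and at the one concentration tested, this added ethyl leaves compound 4 at the same low level as compound 1. The data shown offer no explanation for this result.

As far as these compounds go, it remains open whether a longer straight chain such as hexyl, or a chain ending in an amine or a carboxylic acid, would give a different number at this ester. From the compounds shown here alone, the (pentan-3-yl)oxy change has also been read only with furan-2-yl, so its effect alongside furan-3-yl or thiophen-3-yl remains unknown.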